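Cytotoxicity of a Cyclic Sulfonate Series: Benzyl Ether Variation

The source may hold more compounds than are shown below. What is called first, only, known or untested is meant among the compounds shown, and "the series" means these compounds.

Measured compounds:
Compound 1, `CCC1(Cc2ccccc2)OS(=O)(=O)C=C1OCc1ccc(Cl)c(Cl)c1`: 36700 nM
Compound 2, `O=S1(=O)C=C(OCc2ccccc2)C(Cc2ccccc2)(Cc2ccccc2)O1`: 200000 nM
Compound 3, `CC1(Cc2ccccc2)OS(=O)(=O)C=C1OCc1ccccc1`: 68000 nM

In an ADME assay on HEL cells (Homo sapiens) for cytotoxicity, with a stated time of 3 days (on this read-out lower numbers stand for higher toxicity in this test and higher numbers for lower toxicity in this test), compound 1 gives the lowest of the three numbers. Its nearest neighbour is compound 3, whose number lies higher but within the scatter; compound 2 lies furthest, beyond the scatter. The one step that is shown, a 2.9-fold lower number from compound 2 to compound 3 (0.47 log units; beyond the scatter), concerns the saturated ring carbon of the core and not the benzyl ether.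

Compound 4, `CCC1(Cc2ccccc2)OS(=O)(=O)C=C1OCc1ccc(C)cc1`, is the unmeasured compound. It differs from compound 1 in one place: 4-methylphenyl in place of 3,4-dichlorophenyl on a saturated chain carbon bound to an oxygen on an unsaturated carbon. No shown step bears on this part of the molecule. Compound 3 carries an unsubstituted phenyl at the same place, but it also differs from compound 1 at the ring carbon, so only the two values can be compared, and they lie within the scatter of each other. On that thin basis no step beyond the scatter in this assay is expected for compound 4; the estimated change is a 1.4-fold higher number from compound 1 to compound 4 (0.13 log units; within the scatter). Compound 4 is therefore expected to give about 50000 nM, within a range from 18000 nM to 150000 nM.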

Compound 4, half-maximal cytotoxic concentration: 41500 nM
For compound 4 the middle estimate is 1.2-fold (0.08 log units) above the measured one, and the stated range covers the measured number.
By their numbers in this assay, from the lowest: compounds 1, 4 and 3 (each within the scatter of the next); then compound 2.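

In this assay, going by these compounds alone, the step at the benzyl ether can now be read directly: it is a 1.1-fold higher number from compound 1 to compound 4 (0.05 log units; within the scatter), whereas the earlier compounds offered only a comparison that also differed at the ring carbon. Within the data shown here, with the rest of the molecule held constant, 4-methylphenyl in place of 3,4-dichlorophenyl therefore gives no difference beyond the scatter, even though the two chlorine atoms leave and a single methyl carbon enters, while the only step beyond the scatter so far, a 2.9-fold lower number from compound 2 to compound 3 (0.47 log units; beyond the scatter), lies at the ring carbon of the core. No measurement available here accounts for this result.

From the compounds shown here alone, it remains open whether a phenyl ring carrying an amine or a carboxylic acid, or a longer chain between the ether oxygen and the ring, would give a number beyond the scatter from that of compound 1 at this place. Also open, going by these compounds, is whether the same exchange of 3,4-dichlorophenyl and 4-methylphenyl would read alike on the cores of compound 2 and compound 3, since this position rests on a single pair.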